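Sigma-1 binding: one more chain carbon after compound 2

The compounds below may be only part of what the source reports. "The series", "measured", "known", "first", "only" and "open" are said of these compounds alone.

Measured so far:
compound 1 `CCN(CC)CCCCCCOc1ccc2oc(-c3ccccc3)cc(=O)c2c1` — 100 nM
compound 2 `O=c1cc(-c2ccccc2)oc2cc(OCCCCCCN3CCC(O)CC3)ccc12` — 70 nM

In an assay on isolated protein (Cavia porcellus) with Sigma non-opioid intracellular receptor 1 (Homo sapiens) as the target, read by radioligand binding (a higher number here means a weaker inhibitor, a lower number a stronger inhibitor), compound 1 gives 100 nM and compound 2 gives 70 nM; compound 2 holds the lowest of the two numbers, with compound 1 within the scatter of it, so no order between them can be read. Compound 3 `O=c1cc(-c2ccccc2)oc2cc(OCCCCCCCN3CCC(O)CC3)ccc12` differs from compound 2 by (4-hydroxypiperidin-1-yl)methyl in place of 4-hydroxypiperidin-1-yl on a saturated chain carbon, six bonds along the chain from an oxygen on an aromatic ring. For the measured compounds named here, no measured pair shows this change, so nothing beyond the scatter is expected in either direction. The estimated step is a 1.2-fold lower number from compound 2 to compound 3 (0.07 log units; within the scatter), inside the scatter. Compound 3 is expected at 60 nM, within 25 nM to 150 nM.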

Compound 3, half-maximal inhibitory concentration: 19 nM
Compound 3: middle estimate off by 3.2-fold (0.50 log units), on the high side; measured number below the stated range.
By their numbers in this assay, from the lowest: compound 3; then compounds 2 and 1 (each within the scatter of the next).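

At the saturated chain carbon six bonds along the chain from an oxygen on an aromatic ring, (4-hydroxypiperidin-1-yl)methyl in place of 4-hydroxypiperidin-1-yl gives, in this assay, a 3.7-fold lower number from compound 2 to compound 3 (0.57 log units; beyond the scatter). For the compounds shown here, this is the only step so far, and it shows that one added chain carbon can move the number beyond the scatter. Nothing measured on these compounds explains the step.

Going by these compounds, whether 2-(4-hydroxypiperidin-1-yl)ethyl at this carbon lowers the number further remains open. Also open, on these data alone, is whether the longer chain has the same effect with a morpholin-4-yl end group.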